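The source may hold more compounds than are shown below. What is called first, only, known or untested is meant among the compounds shown, and "the series" means these compounds.

The measured compounds:
Compound 1, `Cc1cc(Nc2nc(NCc3ccc(F)cc3F)nc3cc(F)ccc23)n[nH]1`, gives 62 nM in an assay for inhibition of high affinity nerve growth factor receptor (Homo sapiens), read by HTRF, with a stated time of 30 min, in the presence of a further agent that is not named here; a lower number here means a stronger inhibitor, a higher number a weaker inhibitor.
Compound 2, `Cc1ccc2c(Nc3cc(C)[nH]n3)nc(NCc3ccc(F)cc3F)nc2c1`, gives 27 nM in this assay.

Compound 2 stands at the lowest of the two numbers seen so far. For the measured compounds named here, the only step measured, a 2.3-fold lower number from compound 1 to compound 2 (0.36 log units; beyond the scatter), separates it from compound 1 and lies beyond the scatter.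

Compound 3, `Cc1cc(Nc2nc(NCc3ccc(F)cc3F)nc3cc(C(F)(F)F)ccc23)n[nH]1`, has not yet been measured. It differs from compound 2 in one place: trifluoromethyl in place of methyl on an aromatic carbon. Going by the values given here, the one measured step bears on this change only loosely: it exchanged groups on the same aromatic carbon and moved the number modestly, as a 2.3-fold lower number from compound 1 to compound 2 (0.36 log units; beyond the scatter) shows. A shift of no greater size, in either direction, is therefore expected for compound 3, and the estimated step is a 1.5-fold higher number from compound 2 to compound 3 (0.17 log units; within the scatter), a slight weakening. Compound 3 is thus expected to give about 40 nM in this assay, with a likely range from 15 nM to 110 nM.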

Compound 3, half-maximal inhibitory concentration: 57 nM
Beside the measured number, compound 3's estimate is 1.4-fold (0.15 log units) below it; measured number inside the range.
By their numbers in this assay, from the lowest: compound 2; then compounds 3 and 1 (each within the scatter of the next).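

In this assay, the step from methyl to trifluoromethyl on this aromatic carbon gives a 2.1-fold higher number from compound 2 to compound 3 (0.32 log units; beyond the scatter) and so takes back about what the earlier step from fluoro to methyl gained. Fluoro and trifluoromethyl cannot be told apart at this carbon, with a 1.1-fold lower number from compound 1 to compound 3 (0.04 log units; within the scatter) as their comparison, which leaves methyl as the only one of the three groups with a lower number, and only by a modest margin. Nothing measured here explains why these groups fall in this order.

On these data alone, what remains open is whether a group such as ethyl, methoxy or an amine on this carbon would give a lower number than methyl or a higher one. As far as these compounds go, it is also open whether a plain hydrogen there would match fluoro, or whether these three groups would keep their order elsewhere on the same ring.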